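Amide-region variation in a nitrile-bearing urea series

The source may hold more compounds than are shown below. What is called first, only, known or untested is meant among the compounds shown, and "the series" means these compounds.

Measured so far:
- compound 1 `CC(C)N(CCN(C(=O)Nc1ccc(F)c(Cl)c1)C1CC[C@]2(c3cccc(C#N)c3)CC2C1)C(C)C`: 4.98 nM
- compound 2 `N#Cc1cccc([C@]23CCC(N(CCN4C=CC=CC=C4)C(=O)Nc4ccc(F)c(Cl)c4)CC2C3)c1`: 15 nM

In a functional assay for antagonist activity at melanin-concentrating hormone receptor 1 (Homo sapiens) (on this read-out higher numbers stand for weaker inhibition and lower numbers for stronger inhibition), compound 1 gives 4.98 nM. For the measured compounds named here, compound 2 gives 15 nM in this assay and so stands highest of the two numbers, with compound 1 as its nearest neighbour; the step of a 3.0-fold higher number from compound 1 to compound 2 (0.48 log units; beyond the scatter) is modest but beyond the scatter and is the only measured step at this part of the molecule.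

Compound 3 `CC(=O)N1CCC(CN(C(=O)Nc2ccc(F)c(Cl)c2)C2CC[C@]3(c4cccc(C#N)c4)CC3C2)CC1` is not yet measured. It differs from compound 2 by a group of 9 heavy atoms (7 carbon, 1 nitrogen, 1 oxygen; one six-membered non-aromatic ring with 1 hetero atom) in place of a group of 8 heavy atoms (7 carbon, 1 nitrogen; one seven-membered non-aromatic ring with 1 hetero atom), on a saturated chain carbon bound to an amide-type nitrogen. Going by the values given here, the only step that bears on it is the one from compound 1 to compound 2, which shows that exchanging the group on this chain carbon shifts the number by a modest amount. No measured pair contains the 1-acetylpiperidin-4-yl group, so its direction cannot be read from the shown data. The expectation is therefore a step of modest size or none beyond the scatter, a 1.5-fold lower number from compound 2 to compound 3 (0.18 log units; within the scatter), with a wide range. Compound 3 is estimated at 10 nM in this assay, between 3 nM and 35 nM.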

Compound 3, inhibition constant: 312 nM
Compound 3: middle estimate off by 31-fold (1.49 log units), on the low side; measured number outside the range, above it.
By their numbers in this assay, from the lowest: compound 1; then compound 2; then compound 3.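

In this assay, the group on this saturated chain carbon bound to an amide-type nitrogen can shift the number far more than the earlier pair suggested: 1-acetylpiperidin-4-yl gives a 21-fold higher number from compound 2 to compound 3 (1.32 log units; beyond the scatter) and a 63-fold higher number from compound 1 to compound 3 (1.80 log units; beyond the scatter), both large, against the modest 3.0-fold higher number from compound 1 to compound 2 (0.48 log units; beyond the scatter). Compound 3 therefore stands as the weakest of the three, with its steps to compound 1 and compound 2 both beyond the scatter, so tolerance at this place does not extend to every group of similar size. Nothing measured on these compounds accounts for the drop.

The compounds shown do not separate the contribution of the acetyl group from that of the piperidine ring, and a piperidin-4-yl group without the acetyl, or one carrying a methyl group on the ring nitrogen, would address that point. Also open, as far as these compounds go, is how this place responds to a simple tertiary amine smaller than the diisopropylamino group, such as dimethylamino, or to a carboxylic acid at the end of a longer chain.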